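A few compounds are considered here, and "the series" means these few. Any claim that something is new, unique, unknown or untested is made for them only; others in the source may bear on it.

Working notes on the series in an assay on isolated protein for agonist activity at Bile acid receptor (Homo sapiens), read by TR-FRET, with a stated time of 3 h, in the absence of a further agent; a higher number here means that more compound is needed for the effect, a lower number that less compound is needed. Compound 1, `O=C(O)COc1cccc(NC(=O)c2ccc(Oc3ccccc3)cc2)c1`, sits at the limit of the assay; in this assay compound 1 gives > 10000 nM, which is a limit and not a number, as recorded in the limit of > 10000 nM in this assay, at which 1 of the 3 values shown sits. Compound 2, `COc1cccc(C(=O)Nc2cccc(C(=O)O)c2)c1`, gives 1040 nM in this assay. Compound 3, `CC(C)CCOc1ccc(C(=O)Nc2cccc(C(=O)O)c2)cc1`, gives 215 nM in this assay. Among the two numbers recorded, compound 2 stands highest; its nearest neighbour is compound 3, whose number is lower by a gap beyond the scatter, though compound 3 differs from compound 2 in more than one place, so only the two values can be set side by side.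

Compound 4, `O=C(O)c1cccc(NC(=O)c2cccc(OCC3CC3)c2)c1`, carries the change cyclopropyl in place of hydrogen on a saturated chain carbon bound to an oxygen on an aromatic ring relative to compound 2. Going by the values given here, no single-point step between measured compounds is available to size this change. The expectation for the step from compound 2 to compound 4 in this assay is a moderate move toward a lower number, a 2.6-fold lower number from compound 2 to compound 4 (0.41 log units; beyond the scatter), beyond the scatter but not large. Compound 4 is thus estimated at 400 nM in this assay, with a range from 150 nM to 1200 nM.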

Compound 4, half-maximal effective concentration: 1260 nM
The estimate for compound 4 lay 3.2-fold (0.50 log units) below the measured number; measured number outside the range, above it.
By their numbers in this assay, from the lowest: compound 3; then compounds 2 and 4 (each within the scatter of the next). At a limit, above all of these: compound 1.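

Going by these compounds alone, the step from methoxy to cyclopropylmethoxy is the first change that can be sized in one place, and in this assay it reads a 1.2-fold higher number from compound 2 to compound 4 (0.08 log units; within the scatter). On a saturated chain carbon bound to an oxygen on an aromatic ring, cyclopropyl in place of hydrogen therefore leaves compound 2 and compound 4 indistinguishable, so the 3 carbon atoms of the cyclopropyl are accommodated here without a gain or a loss that this assay can resolve. Nothing on hand bears on why this step reads as it does.

This single step leaves open whether the same reading extends to other groups at this carbon, such as a longer straight chain or an amine. It also leaves open whether cyclopropyl at this place would read the same on a different core.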